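Hydrogen for bromo on the aryl group: compound 2 to 3

A few compounds are considered here, and "the series" means these few. Any claim that something is new, unique, unknown or untested is made for them only; others in the source may bear on it.

In an assay on cells for inhibition of Amine oxidase [flavin-containing] A (Homo sapiens), read by fluorescence and Amplex Red, with a stated time of 15 min (a lower number here means a stronger inhibitor, a higher number a weaker inhibitor), compound 1 `Cc1cccc2cc(-c3ccccc3Br)oc12` gives 100000 nM. Compound 2 `Cc1cccc2cc(-c3cccc(Br)c3)oc12` in this assay gives > 100000 nM, which is a limit of the assay and not a number. Compound 2 thus stands at the limit of > 100000 nM in this assay, at which 1 of the 2 values shown sits, so its position relative to compound 1 cannot be fixed beyond that. The change to compound 3 `Cc1cccc2cc(-c3ccccc3)oc12` is hydrogen in place of bromo on an aromatic carbon. Going by the values given here, no step between measured compounds is available, so the expectation for this change rests on the two values alone, both of which sit at or beyond the upper edge of what this assay resolves; no step beyond the scatter is expected in either direction, and a fair chance remains that compound 3 again returns only a limit. The estimated value for compound 3 in this assay is 100000 nM, with a range of 30000 nM to 300000 nM. This corresponds to an expected a number no higher from compound 2 to compound 3 (the limit leaves the size open).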

Compound 3, half-maximal inhibitory concentration: 100000 nM
The estimate for compound 3 equals the measured number at the digits printed; low and high end bracket the measured number.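

In this assay, going by these compounds alone, hydrogen in place of bromo on an aromatic carbon gives no change at the digits printed from compound 1 to compound 3 (within the scatter), the first readable step. The same replacement gives a number no higher from compound 2 to compound 3 (the limit leaves the size open). Compound 3 still returns a number rather than a limit. Compound 2 holds a limit and not a number: the limit of > 100000 nM in this assay, at which 1 of the 3 values shown sits.

As far as these compounds go, what an amine or a carboxylic acid on the aryl group would do in this assay stays open, as does whether any group there can bring the series to a lower number. The contribution of the methyl group on the shared core is also open, as it is the same in all the compounds shown.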